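This account rests on a few compounds, and the source may have more. Where it says the series, first, only, none or still open, it means among the compounds named here.

Working notes on the series. The compounds share the core of compound 3 `CC(C)c1ncncc1-c1nc2cc(F)c(F)cc2n1C1CC1` and differ only in the group on the six-membered aromatic ring with 2 nitrogen. Within the data shown here, in an ADME assay on cells for inhibition of cytochrome P450 11B1, mitochondrial (Homo sapiens), read by HPLC, with a stated time of 60 min (a lower number here means a stronger inhibitor, a higher number a weaker inhibitor), compound 3 gives 1910 nM, the lowest of the three numbers so far. Compound 1 `Fc1cc2nc(-c3cncnc3)n(C3CC3)c2cc1F` gives 2270 nM in this assay, and the step of a 1.2-fold lower number from compound 1 to compound 3 (0.07 log units; within the scatter) is within the scatter, so these two cannot be ordered. Compound 2 `Cc1ncncc1-c1nc2cc(F)c(F)cc2n1C1CC1` gives 4160 nM in this assay; the step of a 2.2-fold lower number from compound 2 to compound 3 (0.34 log units; beyond the scatter) is modest but beyond the scatter, whereas a 1.8-fold higher number from compound 1 to compound 2 (0.26 log units; within the scatter) is within it.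

Compound 4 `N#Cc1ncncc1-c1nc2cc(F)c(F)cc2n1C1CC1` differs from compound 3 by cyano in place of isopropyl on an aromatic carbon. Among the measured compounds shown here, no measured step involves a cyano group, so the bearing steps are indirect: a 1.2-fold lower number from compound 1 to compound 3 (0.07 log units; within the scatter), a 2.2-fold lower number from compound 2 to compound 3 (0.34 log units; beyond the scatter) and a 1.8-fold higher number from compound 1 to compound 2 (0.26 log units; within the scatter) together show that exchanging the group at this position moves the number only a little in either direction. Compound 4 is therefore expected to give about 3000 nM, within 900 nM to 10000 nM. The estimated step of a 1.6-fold higher number from compound 3 to compound 4 (0.20 log units; within the scatter) is thus small, with no confident direction beyond the scatter.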

Compound 4, half-maximal inhibitory concentration: 4990 nM
Estimate against measurement, compound 4: 1.7-fold (0.22 log units) below; the range from low to high includes it.
By their numbers in this assay, from the lowest: compounds 3, 1, 2 and 4 (each within the scatter of the next, the first and the last beyond it).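

In this assay, among these compounds, cyano is the first group at this position, on an aromatic carbon next to the ring nitrogen, whose step from hydrogen lies beyond the scatter (a 2.2-fold higher number from compound 1 to compound 4 (0.34 log units; beyond the scatter)), and its exchange for isopropyl is also modest but beyond it (a 2.6-fold higher number from compound 3 to compound 4 (0.42 log units; beyond the scatter)). Cyano and methyl cannot be ordered (a 1.2-fold higher number from compound 2 to compound 4 (0.08 log units; within the scatter)), so two quite different groups give numbers within the scatter of each other, and the whole span across the four compounds remains modest. No measurement available here bears on why the number moves with this change.

From the compounds shown here alone, whether an amine, a methoxy group or a carboxylic acid at this position would take the number outside this narrow span remains open. So does whether a longer chain than isopropyl would go with a lower number.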